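The source may report more compounds than this note shows. Statements on the series, on what has been measured and on what is new or still open speak of the compounds shown alone.

Measured so far in a functional assay on HL-60 cells (Homo sapiens) for antiproliferative activity; a higher number here means a weaker inhibitor of growth, a lower number a stronger inhibitor of growth:
compound 1 `COCCCCCCCCCCCCCCC/C=C1\CC(CO)(COC(=O)C(C)(C)C)OC1=O` gives 4.65 ug/mL.
compound 2 `COC(=O)CCCCCCCCCCCCCC/C=C1\CC(CO)(COC(=O)C(C)(C)C)OC1=O` reaches only the assay limit > 10 ug/mL.
compound 3 `CC(=O)OCCCCCCCCCCCCCCC/C=C1\CC(CO)(COC(=O)C(C)(C)C)OC1=O` reaches only the assay limit > 10 ug/mL.

Among the measured compounds shown here, compound 1 carries the only numeric value in this assay; the other two values are limits (the limit of > 10 ug/mL in this assay, at which 2 of the 3 values shown sit). Compound 4 `CC(=O)NCCCCCCCCCCCCCCC/C=C1\CC(CO)(COC(=O)C(C)(C)C)OC1=O` differs from compound 1 by acetamido in place of methoxy on a saturated chain carbon, ten or more bonds along the chain from a double-bonded chain carbon. The two measured steps change the same chain end: an at least 2.1-fold higher number from compound 1 to compound 2 (0.33 log units; beyond the scatter) and an at least 2.1-fold higher number from compound 1 to compound 3 (0.33 log units; beyond the scatter). Both replacements at that position weakened growth inhibition at least modestly, so a weakening is expected for compound 4 as well, a 2.6-fold higher number from compound 1 to compound 4 (0.41 log units; beyond the scatter). Compound 4 is therefore estimated at 12 ug/mL, expected between 5 ug/mL and 30 ug/mL, and may well return only a limit in this assay.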

Compound 4, concentration for 50% growth inhibition: > 10 ug/mL
Compound 4 ended at the assay's limit; the forecaster's own chance of this, stated with the estimate: 55%; the middle value does not contradict the limit.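

In this assay, acetamido in place of methoxy at this chain end gives an at least 2.1-fold higher number from compound 1 to compound 4 (0.33 log units; beyond the scatter), so the weakening seen with methoxycarbonyl and acetoxy also holds for a nitrogen-linked group carrying a hydrogen-bond donor. Compound 4 reads > 10 ug/mL, which is a limit and not a number. The steps among compound 2, compound 3 and compound 4 cannot be read, and these three stay unordered: the limit of > 10 ug/mL in this assay, at which 3 of the 4 values shown sit.

Going by these compounds, the true size of each loss remains open. So does whether a terminal amine, a carboxylic acid or a longer chain would hold or improve on compound 1.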